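The source may hold more compounds than are shown below. What is called first, only, known or untested is meant among the compounds shown, and "the series" means these compounds.

Compound 1, `ClCc1ccccc1Cn1cnc2c(Cl)ncnc21`: 46800 nM
Compound 2, `ClCc1cccc(Cn2cnc3c(Cl)ncnc32)c1`: 16200 nM

Both numbers come from a functional assay on TK-10 cells (Homo sapiens) for cytotoxicity, read by sulforhodamine B assay, with a stated time of 48 h; a lower number here means a stronger inhibitor of growth, a higher number a weaker inhibitor of growth. Compound 2 holds the lower of the two values, and its gap to compound 1 lies beyond the usual scatter, so of these two it is the stronger inhibitor of growth. Compound 3, `ClCc1cccc(Cn2cnc3c(Cl)nc(Cl)nc32)c1`, has not yet been measured. It differs from compound 2 by chloro in place of hydrogen on an aromatic carbon. Among the measured compounds shown here, no measured pair shows this change, so its effect cannot be read from the data; a small step in either direction, or none beyond the scatter, seems the most plausible outcome. Compound 3 is therefore expected near 12000 nM, between 4000 nM and 40000 nM. That estimate amounts to an expected step of a 1.4-fold lower number from compound 2 to compound 3 (0.13 log units; within the scatter).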

Compound 3, concentration for total growth inhibition: 3980 nM
Compound 3: the middle estimate sits 3.0-fold (0.48 log units) above what was measured, and the stated range ends above it.
By their numbers in this assay, from the lowest: compound 3; then compound 2; then compound 1.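

In this assay, chloro in place of hydrogen on the aromatic carbon between two ring nitrogen atoms gives a 4.1-fold lower number from compound 2 to compound 3 (0.61 log units; beyond the scatter), beyond the scatter. This shows that the carbon is not a silent spot: one added heavy atom there changes the result, something compound 1 and compound 2 could not show, since they differ elsewhere in the structure. Nothing available explains this step. Going by these compounds, whether only chloro does this remains open. An amine, a methoxy group or a longer chain on that carbon could move the number either way.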